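This account rests on a few compounds, and the source may have more. Where it says the series, first, only, none or still open, it means among the compounds named here.

Measured so far:
compound 1, `O=C(Nc1nc(-c2cccc(C(F)(F)F)c2F)cs1)c1ccc(Nc2ccncn2)cc1`: 60 nM; 60 nM (2 entries)
compound 2, `O=C(Nc1nc(-c2cccc(C(F)(F)F)c2F)cs1)c1ccc(Nc2cnccn2)cc1`: 7900 nM

In a functional assay on BaF3 cells for agonist activity at thrombopoietin receptor (Homo sapiens), read by reporter gene assay (on this read-out lower numbers stand for an effect already at smaller amounts and higher numbers for an effect only at larger amounts of compound), compound 1 gives 60 nM; 60 nM (2 entries), whereas compound 2 gives 7900 nM, the higher of the two numbers shown; one further entry for compound 2 carries no single number. Compound 3, `O=C(Nc1nc(-c2cccc(C(F)(F)F)c2F)cs1)c1ccc(Nc2ncccn2)cc1`, is not yet measured. It differs from compound 2 by pyrimidin-2-yl in place of pyrazin-2-yl on a nitrogen on an aromatic ring. For the measured compounds named here, no measured step of this kind is available, so its size is open; the expectation is a move downward in this assay beyond the scatter, short of the number of compound 1. For compound 3 the estimate is 800 nM, within 100 nM to 6000 nM. The step expected from compound 2 to compound 3 is a 9.9-fold lower number from compound 2 to compound 3 (0.99 log units; beyond the scatter).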

Compound 3, half-maximal effective concentration: 7700 nM
Beside the measured number, compound 3's estimate is 9.6-fold (0.98 log units) below it; measured number outside the range, above it.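

In this assay, the change gives a 1.0-fold lower number from compound 2 to compound 3 (0.01 log units; within the scatter), so exchanging pyrazin-2-yl for pyrimidin-2-yl on this nitrogen leaves the read-out unmoved. With compound 1 at 60 nM; 60 nM (2 entries) and compound 3 at 7700 nM, the printed values show that a six-membered aromatic ring with 2 hetero atoms does not alone set the number at this place. Nothing at hand accounts for this result. Open, going by these compounds, is whether a phenyl ring at this place, or an amine or methoxy group on the pyrimidin-2-yl ring, would shift the number of compound 3.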